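Fluoro to Cyano on the Sulfonyl Aryl Ring

This account rests on a few compounds, and the source may have more. Where it says the series, first, only, none or still open, it means among the compounds named here.

Measured compounds:
compound 1 `Cc1ccc(S(=O)(=O)c2cnc3ccc(Cl)cc3c2N2CCC(C)CC2)cc1` — 95%
compound 2 `Cc1ccc(S(=O)(=O)c2cnc3ccc(Cl)cc3c2N2CCC(C)CC2)cc1C` — 84%
compound 3 `CC1CCN(c2c(S(=O)(=O)c3ccc(F)cc3)cnc3ccc(Cl)cc23)CC1` — 89%

The three measured compounds share one core and differ only in the ring carried on the sulfonyl sulfur. In an assay on isolated protein for displacement of a labelled ligand from metabotropic glutamate receptor 5 (Homo sapiens), with a stated time of 60 min, tested at 1 uM (on this read-out higher numbers stand for more inhibition at the one concentration tested (going by the name of the read-out) and lower numbers for less inhibition), compound 1 gives 95%, compound 2 gives 84% and compound 3 gives 89%. Compound 3 lies within the scatter of both neighbours: the change a number 6 percentage points lower from compound 1 to compound 3 (within the scatter) and the change a number 5 percentage points higher from compound 2 to compound 3 (within the scatter) are each too small to rank it. Within the data shown here, only the step of a number 11 percentage points lower from compound 1 to compound 2 (beyond the scatter), methyl in place of hydrogen on an aromatic carbon, is modest and beyond the scatter.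

Compound 4 `CC1CCN(c2c(S(=O)(=O)c3ccc(C#N)cc3)cnc3ccc(Cl)cc23)CC1` is reached from compound 3 by cyano in place of fluoro on an aromatic carbon. Among the measured compounds shown here, the steps that bear on this are the two that also alter the group on that same ring: fluoro in place of methyl, and 4-fluorophenyl in place of 3,4-dimethylphenyl, both within the scatter. A single change at the place para to a large group has so far moved the number little, so a cyano there is expected to behave alike, with at most a small drift and no step beyond the scatter.

For compound 4 in this assay the estimate is 85%, between 70% and 96%. This means an expected step of a number 4 percentage points lower from compound 3 to compound 4 (within the scatter).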

Compound 4, a percentage reported as inhibition, at one concentration (the size of the read-out at that concentration, not a potency): 31%
Compound 4: the middle estimate sits 54 percentage points above what was measured, outside the stated range (below it).
By their numbers in this assay, from the lowest: compound 4; then compounds 2, 3 and 1 (each within the scatter of the next, the first and the last beyond it).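

In this assay, the place para to a large group on the sulfonyl aryl ring proves not to accept every group alike: cyano in place of fluoro gives a number 58 percentage points lower from compound 3 to compound 4 (beyond the scatter), far more than the earlier changes on this ring suggested. Among these compounds, compound 4 also stands apart from the other two neighbours, with a number 53 percentage points lower from compound 2 to compound 4 (beyond the scatter) and a number 64 percentage points lower from compound 1 to compound 4 (beyond the scatter), whereas the widest gap among the earlier compounds was only a number 11 percentage points lower from compound 1 to compound 2 (beyond the scatter), so methyl and fluoro at this place say little about how cyano will behave. Cyano brings a triple bond and a hydrogen-bond acceptor that fluoro lacks, but nothing available here shows what lies behind the fall.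

The compounds shown leave open whether this fall is peculiar to cyano or is shared by other groups at the same place, such as a methoxy, an amide or a carboxylic acid. They also leave open whether cyano would give a similar number if it sat at another carbon of the same ring.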